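Compound 1 to compound 3: swapping the 4-chlorophenyl group

The source may hold more compounds than are shown below. What is called first, only, known or untested is meant among the compounds shown, and "the series" means these compounds.

For the measured compounds named here, in a functional assay on PANC-1 cells (Homo sapiens) for cytotoxicity, read by MTT assay, with a stated time of 72 h (on this read-out higher numbers stand for weaker inhibition and lower numbers for stronger inhibition), compound 1 (`O=C1C(Nc2ccc(-c3ccc(Cl)cc3)cc2)=CC(=O)c2ncncc21`) gives 4400 nM and stands within the scatter of the only other measured compound. That is compound 2 (`O=C1C(Nc2cccc(-c3ccccc3)c2)=CC(=O)c2ncncc21`) at 2300 nM and the two values cannot be told apart. Compound 3 (`CN1CCN(c2ccc(NC3=CC(=O)c4ncncc4C3=O)cc2)CC1`) has not yet been measured. It keeps the core of compound 1 and carries 4-methylpiperazin-1-yl in place of 4-chlorophenyl on an aromatic carbon, para to a large group (4-methylpiperazin-1-yl in place of 4-chlorophenyl on an aromatic carbon). Going by the values given here, the series offers no measured step between two compounds that differ in one place, so the effect of this exchange in this assay remains open. An expectation can lean only on the level set by compound 1 at 4400 nM and compound 2 at 2300 nM in these notes. A modest move toward a lower number is expected, and a result within the scatter of compound 1 would not be surprising. The estimated step is a 2.4-fold lower number from compound 1 to compound 3 (0.39 log units; beyond the scatter) and its size stays modest. The expected value for compound 3 is 1800 nM (estimated range 500 nM to 6000 nM).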

Compound 3, half-maximal inhibitory concentration: 340 nM
The estimate for compound 3 lay 5.3-fold (0.72 log units) above the measured number, outside the stated range (below it).
By their numbers in this assay, from the lowest: compound 3; then compounds 2 and 1 (each within the scatter of the next).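

In this assay, for the compounds shown here, the place on the aromatic carbon that carries these groups proves sensitive to the exchange: 4-methylpiperazin-1-yl in place of 4-chlorophenyl gives a large step (a 13-fold lower number from compound 1 to compound 3 (1.11 log units; beyond the scatter)), the only reading so far between two compounds that differ in one place. Both groups count 7 heavy atoms, so the step comes with no change in that count; what changes is a six-membered aromatic ring of carbon only giving way to a six-membered non-aromatic ring with 2 hetero atoms and 2 hydrogen-bond acceptors. With a single pair, the step cannot be assigned to any one of these differences, and nothing measured here bears on the reason for it.

Open, from the compounds shown here alone, is whether the lower number depends on the whole 4-methylpiperazin-1-yl group, which a piperazine ring without the methyl group, a morpholine ring or a simple dimethylamino group at the same place would test. Also open, going by these compounds, is whether the same exchange gives a step of similar size on the ring arrangement of compound 2.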